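Oxan-4-yl gives way to 2-methylphenyl

This account rests on a few compounds, and the source may have more. Where it says the series, first, only, none or still open, it means among the compounds named here.

In a physicochemical assay for solubility (on this read-out higher numbers stand for higher solubility and lower numbers for lower solubility), compound 2 (`CNC(=O)c1cc(C(=O)N[C@H]2[C@@H]3COC[C@@H]32)cc2c1OC[C@H]2C1CCOCC1`) gives >= 177 ug/mL, which is a limit and not a number. Compound 1 (`CNC(=O)c1cc(C(=O)N[C@H]2[C@@H]3COC[C@@H]32)cc2c1OC[C@H]2c1cccc(OC)c1`) gives >= 186 ug/mL, which is also a limit. Compound 3 (`CNC(=O)c1cc(C(=O)N[C@H]2[C@@H]3COC[C@@H]32)cc2c1OC[C@H]2c1ccccc1C`) is compound 2 with 2-methylphenyl in place of oxan-4-yl on a saturated ring carbon. Among the compounds with values here, the only measured step that bears on this change is a step that the two limits leave unreadable from compound 1 to compound 2, and it swaps 3-methoxyphenyl for oxan-4-yl at the same place. That step offers no size to carry over, so no step beyond the scatter is expected in this assay. The expected change is an at least 1.0-fold lower number from compound 2 to compound 3 (0.01 log units; that floor lies within the scatter). For compound 3 the estimate is 170 ug/mL, with an expected range of 85 ug/mL to 200 ug/mL.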

Compound 3, solubility: >= 103 ug/mL
Compound 3 ended at the assay's limit; the forecaster's own chance of this, stated with the estimate: 60%; the middle value lies beyond the limit too.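

In this assay, within the data shown here, compound 1, compound 2 and compound 3 all stand as limits and not as numbers, and no step among them can be read. On these data alone, whether 3-methoxyphenyl, oxan-4-yl or 2-methylphenyl gives the highest solubility stays open.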